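Swapping 2-fluorophenyl for thiophen-2-yl on the chain carbon

The source may hold more compounds than are shown below. What is called first, only, known or untested is meant among the compounds shown, and "the series" means these compounds.

In a functional assay on HCT-116 cells (Homo sapiens) for inhibition, read by sulforhodamine B assay (a higher number here means a weaker inhibitor, a lower number a stronger inhibitor), compound 1 (`NS(=O)(=O)OC[C@@H]1C[C@@H](n2nnc3c(N[C@H]4CCc5ccccc54)ncnc32)C[C@@H]1O`) gives 43.2 nM and compound 2 (`NS(=O)(=O)OC[C@@H]1C[C@@H](n2nnc3c(NCc4ccccc4F)ncnc32)C[C@@H]1O`) gives 3860 nM as the higher of the two numbers. Compound 3 (`NS(=O)(=O)OC[C@@H]1C[C@@H](n2nnc3c(NCc4cccs4)ncnc32)C[C@@H]1O`) carries thiophen-2-yl in place of 2-fluorophenyl on a saturated chain carbon bound to a nitrogen on an aromatic ring. Going by the values given here, the only measured step (an 89-fold higher number from compound 1 to compound 2 (1.95 log units; beyond the scatter)) is large, but it put 2-fluorobenzyl in place of 2,3-dihydro-1H-inden-1-yl, a different change. Here the expected step (a 1.1-fold lower number from compound 2 to compound 3 (0.04 log units; within the scatter)) stays within the scatter, with no direction favoured. Compound 3 is estimated at 3500 nM (range 1000 nM to 12000 nM).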

Compound 3, half-maximal inhibitory concentration: > 10000 nM
Compound 3 gave a limit, no number; the forecaster's own chance of this, stated with the estimate: 10%; middle value at least 2.8-fold (0.45 log units) away from the limit.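

Compound 3 gives a limit rather than a number in this assay: the limit of > 10000 nM in this assay, at which 1 of the 3 values shown sits.

Even so, the aromatic ring on this saturated chain carbon is not freely interchangeable: thiophen-2-yl in place of 2-fluorophenyl gives an at least 2.5-fold higher number from compound 2 to compound 3 (0.41 log units; beyond the scatter). Measured against 2,3-dihydro-1H-inden-1-yl, (thiophen-2-yl)methyl gives an at least 230-fold higher number from compound 1 to compound 3 (2.36 log units; beyond the scatter), which leaves the 2,3-dihydro-1H-inden-1-yl group well ahead of both benzyl-type groups.

On these data alone, how far compound 3 lies past its limit stays unknown. As far as these compounds go, it also remains open whether an unsubstituted phenyl or a furan-2-yl on the same chain carbon would match 2-fluorophenyl.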